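Adding Methoxy to a Compound Already at the Limit

The compounds below may be only part of what the source reports. "The series", "measured", "known", "first", "only" and "open" are said of these compounds alone.

In an ADME assay on microsomes from liver (Homo sapiens) for metabolic stability (a higher number here means faster removal of the compound, a lower number slower removal), compound 1 (`C[C@H](NC(=O)Cn1nnc2ccccc2c1=O)c1ccc(C(F)(F)F)cc1F`) gives 17 mL/min/kg. Compound 2 (`C[C@H](NC(=O)Cn1nnc2ccccc2c1=O)c1ccc(OC(F)(F)F)cc1F`) gives < 9.9 mL/min/kg, which is a limit of the assay and not a number. Compound 3 (`COc1cccc2nnn(CC(=O)N[C@@H](C)c3ccc(OC(F)(F)F)cc3F)c(=O)c12`) differs from compound 2 by methoxy in place of hydrogen on an aromatic carbon, with methoxy in place of hydrogen on an aromatic carbon. For the measured compounds named here, the only measured step is an at least 1.7-fold lower number from compound 1 to compound 2 (0.23 log units; that floor lies within the scatter), which put trifluoromethoxy in place of trifluoromethyl. That step changed a different group, so it offers only weak guidance on adding methoxy. Compound 2 sits at the limit of < 9.9 mL/min/kg in this assay, at which 1 of the 2 values shown sits, so only a rise could appear as a number in this assay. A small change is therefore expected, and the estimated step is an at least 1.1-fold higher number from compound 2 to compound 3 (0.04 log units; that floor lies within the scatter). The estimate for compound 3 is 11 mL/min/kg, within an expected range from 7 mL/min/kg to 20 mL/min/kg.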

Compound 3, clearance: 41 mL/min/kg
Beside the measured number, compound 3's estimate is 3.7-fold (0.57 log units) below it; measured number above the stated range.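

In this assay methoxy on this aromatic carbon, ortho to a fused ring and meta to a fused ring, gives the only step shown that lies beyond the scatter (an at least 4.1-fold higher number from compound 2 to compound 3 (0.61 log units; beyond the scatter)). Compound 2 stands at a limit of the assay and not at a number: (the limit of < 9.9 mL/min/kg in this assay, at which 1 of the 3 values shown sits). This position on the shared core is therefore not a silent one: placing methoxy here moves the number up, towards faster removal, and the step printed is only a floor for the real change.

The compounds shown leave open whether this rise belongs to methoxy itself or would also follow a fluorine atom, a hydroxyl or a longer chain such as ethoxy on the same carbon. They also leave open whether methoxy would do the same alongside the trifluoromethyl group of compound 1.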